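This account rests on a few compounds, and the source may have more. Where it says the series, first, only, none or still open, it means among the compounds named here.

Going by the values given here, compound 1 `O[C@@H]1[C@@H](OCc2ccccc2)[C@H](O)[C@@H](COCc2ccccc2)O[C@H]1Cc1ccccc1` is the only one of three compounds here that gives a number in a functional assay on HL-60 cells (Homo sapiens) for antiproliferative activity, read by MTT assay (on this read-out higher numbers stand for weaker inhibition and lower numbers for stronger inhibition), where compound 1 gives 35300 nM. Compound 2 `CCC[C@@H]1O[C@H](COCc2ccccc2)[C@@H](OCc2ccccc2)[C@H](OCc2ccccc2)[C@@H]1O` gives "not active" (no number reported) in this assay, and compound 3 `CC(C)C[C@H]1O[C@H](COCc2ccccc2)[C@@H](OCc2ccccc2)[C@H](OCc2ccccc2)[C@@H]1O` likewise gives "not active" (no number reported), so compound 3 stands without a single number, alongside one further compound without one. Among the compounds with values here, compound 4 `CC(C)C[C@H]1O[C@H](COCc2ccccc2)[C@H](OCc2ccccc2)[C@H](OCc2ccccc2)[C@H]1O` is the next candidate. the two compounds have the same atoms and bonds and differ only in configuration as drawn: 2 of 5 stereo elements differ; a stereocentre at a saturated ring carbon is drawn R in compound 3 and S in compound 4; a stereocentre at a saturated ring carbon is drawn R in compound 3 and S in compound 4 No measured pair differing in only one place is available, so there is nothing to size this step against. Changing the configuration at two saturated ring carbons of a compound that showed no activity is not expected to yield a strong inhibitor; no change beyond the scatter is the expectation. Compound 4 is estimated at 60000 nM, within a range from 20000 nM to 200000 nM, and is most likely again reported without a number.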

Compound 4, half-maximal inhibitory concentration: "not active" (no number reported)
For compound 4 the study gives words and no number, so the estimate cannot be set against anything.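

Compound 3 and compound 4 are both reported as "not active" in this assay, without a number, so no step can be read between them. The compounds shown leave open whether configuration at those two saturated ring carbons affects activity at all.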